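The compounds below may be only part of what the source reports. "The series", "measured", "known", "first", "only" and "open" are said of these compounds alone.

Measured in a toxicity assay on NIH3T3 cells (Mus musculus) for cytotoxicity, read by resazurin assay; on this read-out lower numbers stand for an effect already at smaller amounts and higher numbers for an effect only at larger amounts of compound:
- compound 1 `COC(=O)c1ccc(NCc2cncn2Cc2ccc(-c3ccccc3)cc2)cc1-c1ccccc1`: > 1000 nM
- compound 2 `CC(C)OC(=O)c1ccc(NCc2cncn2Cc2ccc(-c3ccccc3)cc2)cc1-c1ccccc1`: > 10000 nM

Neither entry is a true number. Compound 1 gives > 1000 nM, which is a limit of the assay. Compound 2 gives > 10000 nM, which is also a limit, so its position in this assay is known only as a limit.

The next compound to be tested is compound 3 `CCCC(=O)c1ccc(NCc2cncn2Cc2ccc(-c3ccccc3)cc2)cc1-c1ccccc1`. It carries propyl in place of isopropoxy on a carbonyl carbon, which turns isopropoxycarbonyl into propylcarbonyl: propyl in place of isopropoxy on a carbonyl carbon. The shared core stays the same.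

Among the compounds with values here, only one measured step bears on this change, a step that the two limits leave unreadable from compound 1 to compound 2. It concerns the same part of the molecule, placing isopropyl in place of methyl, but it offers no size to carry over. Because compound 2 gives > 10000 nM, the only available anchor is a limit, so no step beyond the usual scatter is expected in this assay, and no direction can be favoured. The expected change is a number no higher from compound 2 to compound 3 (the limit leaves the size open). The estimated value for compound 3 is 10000 nM, with an expected range from 3000 nM to 30000 nM.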

Compound 3, half-maximal effective concentration: > 10000 nM
Compound 3: a limit, no number; the forecaster's own chance of this, stated with the estimate: 70%; the middle value lies on the limit itself.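

No step can be read among compound 1, compound 2 and compound 3: all three entries are limits of the assay, not true numbers. From the compounds shown here alone, what stays open is the true value of each compound in this assay, and whether swapping the group on the carbonyl carbon shifts that value at all.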